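This account rests on a few compounds, and the source may have more. Where it says the series, first, only, none or still open, it means among the compounds named here.

The series shares one core, carried by compound 1 `C=C(C)C(O)CC/C(C)=C/Cc1c(O)ccc2c1O[C@H](c1ccc(O)cc1)CC2=O`, compound 2 `C=C(CCC=C(C)C)C(O)Cc1c(O)ccc2c1O[C@H](c1ccc(O)cc1)CC2=O` and compound 3 `COC(C=C(C)C)C/C(C)=C/Cc1c(O)ccc2c1O[C@H](c1ccc(O)cc1)CC2=O`, which differ only in the side chain on a saturated chain carbon bound to an aromatic carbon. In a functional assay on KB cells (Homo sapiens) for cytotoxicity, read by MTT assay (on this read-out higher numbers stand for weaker inhibition and lower numbers for stronger inhibition), compound 1 gives only a limit, > 10000 nM. Compound 2 likewise reaches only a limit in this assay, > 10000 nM. Compound 3 also stops at a limit, > 10000 nM. Compound 2 therefore stands where every value shown stands, namely (the limit of > 10000 nM in this assay, at which 3 of the 3 values shown sit). For the measured compounds named here, the step that the two limits leave unreadable from compound 1 to compound 2 cannot be sized, and the same holds for a step that the two limits leave unreadable from compound 1 to compound 3, so no measured step in this assay yields a readable size in either direction.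

Compound 4 `CC(C)=CCC/C(C)=C/Cc1c(O)ccc2c1O[C@H](c1ccc(O)cc1)CC2=O` is the next member. From compound 2 it differs as follows: a group of 9 heavy atoms (9 carbon; no ring) in place of a group of 10 heavy atoms (9 carbon, 1 oxygen; no ring), on a saturated chain carbon bound to an aromatic carbon. Going by the values given here, the two measured steps that bear on this change both sit unreadable between limits and give no direction; the only evidence is that every side-chain variant tested so far rests at the limit in this assay. The expectation for compound 4 is accordingly a step no larger than the scatter, a step that the limit leaves unreadable from compound 2 to compound 4, most probably ending at the limit again. Compound 4 is estimated at 15000 nM, within 5000 nM to 50000 nM.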

Compound 4, half-maximal inhibitory concentration: > 10000 nM
Compound 4: only a limit was reported; the forecaster's own chance of this, stated with the estimate: 70%; the middle value does not contradict the limit.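

Compound 4 gives only a limit in this assay, > 10000 nM, so its steps from compound 1, compound 2 and compound 3 cannot be read. The compounds shown leave open whether any side chain on the shared core gives a numeric value in this assay, and how large any side-chain step is, with the series resting here: the limit of > 10000 nM in this assay, at which 4 of the 4 values shown sit.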